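Cyanopyridinyl Ketone Follows the Pyridinyl Lead

A few compounds are considered here, and "the series" means these few. Any claim that something is new, unique, unknown or untested is made for them only; others in the source may bear on it.

Compound 3 `O=C(CCc1ccc(-c2ccccc2)cc1)c1ncc(-c2cccnc2)o1` stands at the lowest number of the three compounds examined in an assay for inhibition of Fatty-acid amide hydrolase 1 (Rattus norvegicus) (on this read-out lower numbers stand for stronger inhibition and higher numbers for weaker inhibition), where compound 3 gives 1.1 nM. Compound 1 `NC(=O)c1cnc(C(=O)CCc2ccc(Oc3ccccc3)cc2)o1` comes nearest; in this assay compound 1 gives 6.6 nM, a gap beyond the scatter. Compound 2 `COC(=O)c1cccc(-c2cnc(C(O)CCc3ccc(-c4ccccc4)cc3)o2)n1` lies furthest away and in this assay compound 2 gives 9000 nM. Compound 4 `N#Cc1cccc(-c2cnc(C(=O)CCc3ccc(-c4ccccc4)cc3)o2)n1` has not yet been measured. It differs from compound 3 in one place: 6-cyanopyridin-2-yl in place of pyridin-3-yl on an aromatic carbon. Going by the values given here, no step between two measured compounds that differ in one place is available, so the weight of this exchange cannot be read from the data. Compound 4 is expected to show a step of a 1.2-fold lower number from compound 3 to compound 4 (0.09 log units; within the scatter) that stays within the scatter. The estimate for compound 4 is 0.9 nM, within 0.2 nM to 4 nM.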

Compound 4, inhibition constant: 2.9 nM
For compound 4 the middle estimate is 3.2-fold (0.51 log units) below the measured one, within the range that was stated.
By their numbers in this assay, from the lowest: compound 3; then compound 4; then compound 1; then compound 2.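

In this assay the exchange of pyridin-3-yl for 6-cyanopyridin-2-yl next to the ring oxygen gives a 2.6-fold higher number from compound 3 to compound 4 (0.42 log units; beyond the scatter), a modest step, so this position accepts the larger group while compound 4 keeps a low number (2.9 nM). No measurement here bears on why the number rises. The exchange both adds the nitrile and changes how the pyridine is attached, and these two changes cannot be separated. On these data alone, whether a carboxylic acid or an amine in place of the nitrile would keep the number this low also remains open.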